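The compounds below may be only part of what the source reports. "The series", "measured", "known", "first", "only" and "open" are said of these compounds alone.

Working notes on the series. In a functional assay on QG-56 cells (Homo sapiens) for antiproliferative activity (on this read-out lower numbers stand for stronger inhibition and higher numbers for weaker inhibition), compound 1 (`Cn1cncc1C(O)(c1ccc([N+](=O)[O-])cc1)c1cc2cc([N+](=O)[O-])cc(-c3ccccc3)c2o1`) gives 547 nM as the lowest number of the three, compound 2 (`COc1ccc(C(O)(c2cc3cc([N+](=O)[O-])cc(-c4ccccc4)c3o2)c2cncn2C)cc1`) gives 4970 nM as the highest, and compound 3 (`Cn1cncc1C(O)(c1ccc(Cl)cc1)c1cc2cc([N+](=O)[O-])cc(-c3ccccc3)c2o1`) gives 1890 nM and so stands in the middle. Changing the one substituent that differs among these compounds produced a 3.5-fold higher number from compound 1 to compound 3 (0.54 log units; beyond the scatter) and a 2.6-fold lower number from compound 2 to compound 3 (0.42 log units; beyond the scatter) while the widest change is a 9.1-fold higher number from compound 1 to compound 2 (0.96 log units; beyond the scatter) and all three steps are modest but beyond the scatter.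

Compound 4 (`Cn1cncc1C(O)(c1ccc(C(=O)OC(C)(C)C)cc1)c1cc2cc([N+](=O)[O-])cc(-c3ccccc3)c2o1`) carries tert-butoxycarbonyl in place of chloro on an aromatic carbon, para to a large group (tert-butoxycarbonyl in place of chloro on an aromatic carbon). Going by the values given here, no measured compound carries this group, so the measured steps offer a likely size but no direction. The middle position of compound 3 at 1890 nM leaves room for movement either way, and the widest measured step, a 9.1-fold higher number from compound 1 to compound 2 (0.96 log units; beyond the scatter), sets the scale of the uncertainty. No step beyond the scatter is therefore expected in this assay as the central case, although a modest step in either direction remains possible. The expected step is a 1.2-fold lower number from compound 3 to compound 4 (0.07 log units; within the scatter) on this estimate. The estimate for compound 4 is 1600 nM with an expected range from 450 nM to 6000 nM in this read-out.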

Compound 4, half-maximal inhibitory concentration: 6250 nM
The estimate for compound 4 lay 3.9-fold (0.59 log units) below the measured number; measured number above the stated range.
By their numbers in this assay, from the lowest: compound 1; then compound 3; then compounds 2 and 4 (each within the scatter of the next).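

Tert-butoxycarbonyl on this aromatic carbon gives a 3.3-fold higher number from compound 3 to compound 4 (0.52 log units; beyond the scatter) in this assay, which puts this ester with methoxy at the high-number end of the series rather than with chloro. Against methoxy itself, the change gives a 1.3-fold higher number from compound 2 to compound 4 (0.10 log units; within the scatter), so these two groups cannot be told apart here, and the much larger tert-butoxycarbonyl brings no further rise in the number beyond what methoxy already shows. Against nitro, the change gives an 11-fold higher number from compound 1 to compound 4 (1.06 log units; beyond the scatter), the only step in the series graded large, and nitro remains the group with the lowest number, its steps to the other three groups all lying beyond the scatter.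

Nothing available bears on the cause of these differences. Still open, as far as these compounds go, is whether the ester itself matters at this position or only the group's bulk, a question that the carboxylic acid, a methyl ester or a primary amide on the same aromatic carbon could address, and whether an amine there would follow nitro or methoxy.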